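This account rests on a few compounds, and the source may have more. Where it says the series, first, only, none or still open, it means among the compounds named here.

In a functional assay on BXPC-3 cells (Homo sapiens) for antiproliferative activity, read by sulforhodamine B assay, with a stated time of 72 h (on this read-out higher numbers stand for weaker inhibition and lower numbers for stronger inhibition), compound 1 `O=C(c1ccccc1)c1cccc(/C=c2\[nH]c(=O)/c(=C/c3ccccn3)[nH]c2=O)c1` gives 6.27 nM. Compound 3 `CC(C)(C)c1[nH]cnc1/C=c1\[nH]c(=O)/c(=C/c2cccc(C(=O)c3cccnc3)c2)[nH]c1=O` gives 4.05 nM, and these two numbers lie within the scatter of each other. Compound 2 `O=C(c1cccc(/C=c2\[nH]c(=O)/c(=C/c3ccccn3)[nH]c2=O)c1)N1CCC1` reports only a limit, > 500 nM.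

The next structure, compound 4 `CC(C)(C)c1[nH]cnc1/C=c1\[nH]c(=O)/c(=C/c2cccc(C(=O)c3cncs3)c2)[nH]c1=O`, departs from compound 3 at a single place: 1,3-thiazol-5-yl in place of pyridin-3-yl on a carbonyl carbon. For the measured compounds named here, only one measured step bears on this change, and it is large: an at least 79-fold higher number from compound 1 to compound 2 (1.90 log units; beyond the scatter). That step put azetidin-1-yl in place of phenyl on a carbonyl carbon, so it removed the aromatic ring from that carbonyl. Compound 4 keeps an aromatic ring there, as do compound 1 at 6.27 nM and compound 3 at 4.05 nM. Going by the values given here, the large step is therefore not expected to repeat, although no measured step swaps one aromatic ring for another at this carbonyl. The step expected in this assay is a 1.2-fold higher number from compound 3 to compound 4 (0.09 log units; within the scatter), which means none beyond the scatter is anticipated. For compound 4 the expected value is 5 nM, with an estimated range of 2 nM to 15 nM.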

Compound 4, half-maximal inhibitory concentration: 17.1 nM
The estimate for compound 4 lay 3.4-fold (0.53 log units) below the measured number, outside the stated range (above it).
By their numbers in this assay, from the lowest: compounds 3 and 1 (each within the scatter of the next); then compound 4. At a limit, above all of these: compound 2.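

Placing 1,3-thiazol-5-yl in place of pyridin-3-yl on the carbonyl carbon gives a 4.2-fold higher number from compound 3 to compound 4 (0.63 log units; beyond the scatter) in this assay, so the identity of the aromatic ring at this position matters, and not only its presence. For the compounds shown here, the earlier compounds offered only one step here, azetidin-1-yl in place of phenyl, which removed the aromatic ring and gave an at least 79-fold higher number from compound 1 to compound 2 (1.90 log units; beyond the scatter); the new step shows that an exchange keeping an aromatic ring on this carbonyl can also move the number beyond the scatter, though only modestly. Nothing measured here explains the step.

The two rings differ in both ring size and hetero atoms, and this single pair cannot separate those differences. From the compounds shown here alone, how a thiophen-2-yl ring or an open-chain dimethylamino group would read on this carbonyl remains open.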